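A few compounds are considered here, and "the series" means these few. Any claim that something is new, unique, unknown or untested is made for them only; others in the source may bear on it.

In an ADME assay on the whole organism (strain Balb/c) for pharmacokinetics, with Mus musculus as the target, read by LC-MS, at a dose of 3 mg/kg by the intravenous route (on this read-out higher numbers stand for fast clearance and lower numbers for slow clearance), compound 1 (`CC(Oc1ccc(F)c(C(N)=O)c1F)c1nc(-c2ccc(C(F)(F)F)cc2)c(Br)o1`) gives 22 mL/min/kg, the lower of the two numbers available. Compound 2 (`CCCc1oc(COc2ccc(F)c(C(N)=O)c2F)nc1-c1ccc(Cl)cc1`) gives 137 mL/min/kg, a gap beyond the scatter, but the two compounds differ in more than one place, so this gap isolates no single change. Compound 3 (`CC(Oc1ccc(F)c(C(N)=O)c1F)c1nc(-c2ccc(OC(F)(F)F)cc2)c(Br)o1`) keeps the core of compound 1 and carries trifluoromethoxy in place of trifluoromethyl on an aromatic carbon, para to a large group: trifluoromethoxy in place of trifluoromethyl on an aromatic carbon. Within the data shown here, no measured pair shows this change or any other single change, so the only anchor is compound 1 at 22 mL/min/kg. In this assay, a small upward step is expected, with none beyond the scatter. The estimate is a 1.4-fold higher number from compound 1 to compound 3 (0.13 log units; within the scatter). For compound 3, the expected clearance is 30 mL/min/kg, with an estimated range of 13 mL/min/kg to 65 mL/min/kg.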

Compound 3, clearance: 36 mL/min/kg
Beside the measured number, compound 3's estimate is 1.2-fold (0.08 log units) below it; measured number inside the range.
By their numbers in this assay, from the lowest: compounds 1 and 3 (each within the scatter of the next); then compound 2.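

In this assay, among these compounds, trifluoromethoxy in place of trifluoromethyl on an aromatic carbon, para to a large group, gives a 1.6-fold higher number from compound 1 to compound 3 (0.21 log units; within the scatter), the first comparison that isolates a single change. On the core of compound 1, this read-out therefore does not separate the two groups at this position, and the extra oxygen of trifluoromethoxy brings no step beyond the scatter. No measurement at hand bears on what lies behind this result.

Still open, as far as these compounds go, is whether a nitrile or a methoxy group at this position would also stay within the scatter of compound 1. Also open, from the compounds shown here alone, is whether the same exchange gives a step of similar size on the core of compound 2, whose clearance lies well apart from the other two.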